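A few compounds are considered here, and "the series" means these few. Any claim that something is new, unique, unknown or untested is made for them only; others in the source may bear on it.

In a functional assay on MGC-803 cells (Homo sapiens) for cytotoxicity, read by MTT assay, with a stated time of 72 h (on this read-out higher numbers stand for weaker inhibition and lower numbers for stronger inhibition), compound 1 (`CC(C)=C1C(=O)N(c2ccc(Cl)cc2)N(c2ccc(Cl)cc2)C1=O`) gives 39000 nM and compound 2 (`CCC(C)=C1C(=O)N(c2ccc(Cl)cc2)N(c2ccc(Cl)cc2)C1=O`) gives 66500 nM on the shared core. Compound 3 (`CN(C)c1ccc(C=C2C(=O)N(c3ccc(Cl)cc3)N(c3ccc(Cl)cc3)C2=O)cc1`) gives 80200 nM and so stands within the scatter of compound 2 and beyond the scatter from compound 1. Compound 4 (`O=C1C(=Cc2ccc(Br)cc2)C(=O)N(c2ccc(Cl)cc2)N1c1ccc(Cl)cc1`) follows from compound 3 through bromo in place of dimethylamino on an aromatic carbon as 4-(dimethylamino)phenyl gives way to 4-bromophenyl. For the measured compounds named here, the only measured step is a 1.7-fold higher number from compound 1 to compound 2 (0.23 log units; within the scatter) on a saturated chain carbon and not on an aromatic carbon, so no measured pair tests this change. No step beyond the scatter is therefore expected, and a 1.3-fold lower number from compound 3 to compound 4 (0.13 log units; within the scatter) is the estimated outcome in this assay for this change. Compound 4 is expected at 60000 nM (estimated range 25000 nM to 120000 nM).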

Compound 4, half-maximal inhibitory concentration: 16900 nM
Estimate against measurement, compound 4: 3.6-fold (0.55 log units) above; measured number outside the range, below it.
By their numbers in this assay, from the lowest: compound 4; then compounds 1, 2 and 3 (each within the scatter of the next, the first and the last beyond it).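

In this assay bromo in place of dimethylamino on an aromatic carbon, para to a large group, gives a 4.7-fold lower number from compound 3 to compound 4 (0.68 log units; beyond the scatter) and is the first single change among these compounds to pass beyond the scatter. This shows that the number responds to the group at this aromatic position, which the step on the saturated chain carbon did not show. Nothing at hand explains why the number moves with this change.

On these data alone, whether the shift belongs to bromo itself or to the loss of dimethylamino stays open. As far as these compounds go, only these two groups are compared here, and the outcome with chloro, methoxy, nitrile or a carboxylic acid at this position is unknown.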